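Benzamide-linked pyrazole series: trifluoromethyl removal on the amide aryl

This account rests on a few compounds, and the source may have more. Where it says the series, first, only, none or still open, it means among the compounds named here.

Measured compounds in a functional assay on A498 cells (Homo sapiens) for inhibition, read by sulforhodamine B assay, with a stated time of 48 h; on this read-out lower numbers stand for higher toxicity in this test and higher numbers for lower toxicity in this test:
compound 1 `COc1cc(-c2nn(-c3cccc(NC(=O)c4cccc(C(F)(F)F)c4)c3)cc2-c2ccncc2)ccc1Cl` – > 50000 nM
compound 2 `COc1cc(-c2nn(-c3cccc(NC(=O)c4ccc(Cl)c(C(F)(F)F)c4)c3)cc2-c2ccncc2)ccc1Cl` – > 32500 nM
compound 3 `O=C(Nc1cccc(-n2cc(-c3ccncc3)c(-c3ccc(Cl)c(O)c3)n2)c1)Nc1cc(C(F)(F)F)cc(C(F)(F)F)c1` – 16000 nM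

Compound 1 reaches only a limit of this assay, so no number is known for it. Compound 2 likewise reaches only a limit of this assay. Within the data shown here, compound 3 gives a number, the sole readable value of the three. Among the measured compounds shown here, the one step that changes a single place, a step that the two limits leave unreadable from compound 1 to compound 2, cannot be sized, as both ends are limits (the limit of > 50000 nM in this assay, at which 1 of the 3 values shown sits, and (the limit of > 32500 nM in this assay, at which 1 of the 3 values shown sits)).

Compound 4 `COc1cc(-c2nn(-c3cccc(NC(=O)c4ccccc4)c3)cc2-c2ccncc2)ccc1Cl` differs from compound 1 by hydrogen in place of trifluoromethyl on an aromatic carbon. For the measured compounds named here, no measured step in this assay involves removal of a trifluoromethyl, and the only step available is unreadable, so nothing indicates a direction. Compound 1 is itself a limit; the shared core with a benzamide arm has so far given no number in this assay, while the urea of compound 3 gave a weak value. The estimate for compound 4 therefore rests on compound 1 alone and is expected to remain near the limit, with the step of a number no higher from compound 1 to compound 4 (the limit leaves the size open) expected to be small. Compound 4 is expected at 50000 nM, within a range from 15000 nM to 150000 nM.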

Compound 4, concentration lethal to 50% of the cells: > 100000 nM
Compound 4 was reported as a limit (the forecaster's own chance of this, stated with the estimate: 70%); middle value at least 2.0-fold (0.30 log units) away from the limit.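

In this assay compound 4 gives > 100000 nM, which is a limit. Compound 1 and compound 2 also stand only as limits, so neither step to compound 4 can be read. The compounds shown leave open whether hydrogen in place of trifluoromethyl changes the read-out at all, and what number any of these three benzamides would give.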